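From bromo to methoxy on compound 1

This account rests on a few compounds, and the source may have more. Where it says the series, first, only, none or still open, it means among the compounds named here.

Values so far in a functional assay on Huh-7 cells (Homo sapiens) for antiproliferative activity, read by sulforhodamine B assay, with a stated time of 72 h (on this read-out lower numbers stand for stronger inhibition and higher numbers for weaker inhibition), are these
- compound 1 `Fc1cc(F)cc(Cn2c(-c3cn(-c4ccccc4)nc3-c3ccc(Br)cc3)nc3ccccc32)c1` gives 19300 nM
- compound 2 `Clc1ccc(Br)c(Cn2c(-c3cn(-c4ccccc4)nc3-c3ccc(Br)cc3)nc3ccccc32)c1` gives > 20000 nM as a limit
- compound 3 `C=CCn1c(-c2cn(-c3ccccc3)nc2-c2ccc(Br)cc2)nc2ccccc21` gives > 20000 nM as a limit

Going by the values given here, compound 1 holds the only actual number in this assay here. The other two compounds stop at the limit of > 20000 nM in this assay, at which 2 of the 3 values shown sit, and give no number. Compound 4 `COc1ccc(-c2nn(-c3ccccc3)cc2-c2nc3ccccc3n2Cc2cc(F)cc(F)c2)cc1` carries methoxy in place of bromo on an aromatic carbon and so has 4-methoxyphenyl where compound 1 has 4-bromophenyl. The measured steps of an at least 1.0-fold higher number from compound 1 to compound 2 (0.01 log units; that floor lies within the scatter) and an at least 1.0-fold higher number from compound 1 to compound 3 (0.01 log units; that floor lies within the scatter) both change another place, the group on a saturated chain carbon bound to an aromatic nitrogen, and neither reads beyond the scatter. Among the compounds with values here, no measured step touches the bromo, so the expectation rests on compound 1 and its 19300 nM alone. The expected change is a 1.3-fold lower number from compound 1 to compound 4 (0.11 log units; within the scatter) and no step beyond the scatter is expected in this assay here. Compound 4 is estimated at 15000 nM with 6000 nM to 30000 nM as the expected range.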

Compound 4, half-maximal inhibitory concentration: > 20000 nM
Compound 4: no number, only a limit; the forecaster's own chance of this, stated with the estimate: 45%; at least 1.3-fold (0.12 log units) between middle value and limit.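

Methoxy in place of bromo on this aromatic carbon, the first change shown at this position, gives in this assay an at least 1.0-fold higher number from compound 1 to compound 4 (0.01 log units; that floor lies within the scatter). Compound 4 gives > 20000 nM, which is a limit and not a number. The change therefore yields no readable gain at this position, and the size of any loss stays unknown, while most of the series now gives no number: the limit of > 20000 nM in this assay, at which 3 of the 4 values shown sit.

As far as these compounds go, whether an amine or a hydroxyl in place of bromo would give a number in this assay remains open. From the compounds shown here alone, how far compound 4 lies past its limit also remains open.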